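Chloro to methoxy: a small step in growth inhibition

The source may hold more compounds than are shown below. What is called first, only, known or untested is meant among the compounds shown, and "the series" means these compounds.

In a functional assay on MCF7 cells (Homo sapiens) for antiproliferative activity, read by MTT assay, with a stated time of 48 h (on this read-out lower numbers stand for stronger inhibition and higher numbers for weaker inhibition), compound 1 (`COc1ccc(-c2nc(SCC(=O)c3sc(-c4ccccc4)nc3C)nc(N)c2C#N)cc1`) gives 27200 nM and compound 2 (`Cc1nc(-c2ccc(Cl)cc2)sc1C(=O)CSc1nc(N)c(C#N)c(-c2ccc(Cl)cc2)n1`) gives 12500 nM as its value. Compound 2 therefore holds the lower of the two numbers, and the gap between them lies beyond the usual scatter. Compound 3 (`COc1ccc(-c2nc(SCC(=O)c3sc(-c4ccc(Cl)cc4)nc3C)nc(N)c2C#N)cc1`) differs from compound 2 in one place: methoxy in place of chloro on an aromatic carbon, turning 4-chlorophenyl into 4-methoxyphenyl (methoxy in place of chloro on an aromatic carbon). Within the data shown here, no measured pair shows this change alone, so the guide is thin. The higher number of compound 1 at 27200 nM points to a modest weakening in this assay at most, perhaps hardly beyond the scatter. The expected change is an estimated (a 1.4-fold higher number from compound 2 to compound 3 (0.16 log units; within the scatter)). For compound 3 the estimated value is 18000 nM (expected range 8000 nM to 38000 nM).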

Compound 3, half-maximal inhibitory concentration: 10100 nM
Compound 3: middle estimate off by 1.8-fold (0.25 log units), on the high side; low and high end bracket the measured number.
By their numbers in this assay, from the lowest: compounds 3 and 2 (each within the scatter of the next); then compound 1.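

In this assay, methoxy in place of chloro on this aromatic carbon gives a 1.2-fold lower number from compound 2 to compound 3 (0.09 log units; within the scatter), so the two groups cannot be told apart at this position. The change that does go beyond the scatter lies elsewhere, in the 4-chlorophenyl group that compound 3 keeps: chloro in place of hydrogen on an aromatic carbon gives a 2.7-fold lower number from compound 1 to compound 3 (0.43 log units; beyond the scatter). Nothing measured here explains the size of either step.

Chloro and methoxy are only two groups, so how an amine, a carboxylic acid or a longer chain such as butoxy would read at this position remains open. Also open, on these data alone, is whether chloro in place of hydrogen would give a step of similar size if chloro, rather than methoxy, stood on the 4-methoxyphenyl group.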